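Swapping the Bromine for a Nitrile on the Sulfonyl Ring

This account rests on a few compounds, and the source may have more. Where it says the series, first, only, none or still open, it means among the compounds named here.

Measured so far:
Compound 1 `CC(=O)Nc1ccc(S(=O)(=O)NNc2ccc(Br)cc2)cc1`: 85 nM
Compound 2 `O=S(=O)(NNc1ccc(Br)cc1)c1ccc(Br)cc1`: 374 nM

Going by the values given here, in an assay on HeLa cells for inhibition of Indoleamine 2,3-dioxygenase 1 (Homo sapiens), read by spectrophotometry, with a stated time of 24 h (a lower number here means that less compound is needed, a higher number that more compound is needed for the effect), compound 2 gives the higher of the two numbers; its only neighbour is compound 1, and the step of a 4.4-fold higher number from compound 1 to compound 2 (0.64 log units; beyond the scatter). Compound 3 `N#Cc1ccc(S(=O)(=O)NNc2ccc(Br)cc2)cc1` differs from compound 2 by cyano in place of bromo on an aromatic carbon. Among the compounds with values here, only that one measured step bears on this change, and it was modest, so the cyano group is expected to land somewhere between the two measured values. A modest decrease is therefore expected, a 1.9-fold lower number from compound 2 to compound 3 (0.27 log units; within the scatter). For compound 3 the estimate is 200 nM, within 80 nM to 500 nM.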

Compound 3, half-maximal effective concentration: 134 nM
For compound 3 the middle estimate is 1.5-fold (0.17 log units) above the measured one; the measured number falls inside the stated range.
By their numbers in this assay, from the lowest: compounds 1 and 3 (each within the scatter of the next); then compound 2.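

At this position, the change from bromo to cyano alone moves the number in this assay: it gives a 2.8-fold lower number from compound 2 to compound 3 (0.45 log units; beyond the scatter) and so shows that a low number does not depend on the acetamido group. Cyano in place of acetamido gives a 1.6-fold higher number from compound 1 to compound 3 (0.20 log units; within the scatter) and leaves the two compounds within the scatter of each other. Nothing available gives a reason for either result. From the compounds shown here alone, whether an amine or a carboxylic acid at this position would also give a number close to those of compound 1 and compound 3 remains open.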